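Methyl to ethoxy on compound 3

The source may hold more compounds than are shown below. What is called first, only, known or untested is meant among the compounds shown, and "the series" means these compounds.

In a functional assay on FM3A cells (Mus musculus) for antiproliferative activity, with a stated time of 48 h (on this read-out lower numbers stand for stronger inhibition and higher numbers for weaker inhibition), compound 1 (`C=C(Br)C(=O)Nc1ccc(/C=C/C(=O)c2ccccc2)cc1`) gives 3900 nM and compound 2 (`C=C(Br)C(=O)Nc1ccc(/C=C/C(=O)c2ccc(I)cc2)cc1`) gives 8300 nM while compound 3 (`C=C(Br)C(=O)Nc1ccc(/C=C/C(=O)c2ccc(C)cc2)cc1`) gives 2100 nM on the same core. Methyl in place of hydrogen gives a 1.9-fold lower number from compound 1 to compound 3 (0.27 log units; within the scatter) and iodo in place of hydrogen gives a 2.1-fold higher number from compound 1 to compound 2 (0.33 log units; beyond the scatter) while methyl in place of iodo gives a 4.0-fold lower number from compound 2 to compound 3 (0.60 log units; beyond the scatter) in this series. Compound 3 therefore shares the low end of the numbers with compound 1 and stands apart from compound 2.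

Compound 4 (`C=C(Br)C(=O)Nc1ccc(/C=C/C(=O)c2ccc(OCC)cc2)cc1`) carries the next change (ethoxy in place of methyl on an aromatic carbon), ethoxy in place of methyl on an aromatic carbon, para to a large group. All three measured steps bear on it as changes at this same place, but none of them involves ethoxy, so they give a rough scale and no direct guide. The largest of them is modest (a 4.0-fold lower number from compound 2 to compound 3 (0.60 log units; beyond the scatter)). A step no larger than that is expected, most likely a small rise in the number that stays within the scatter. The expected step is a 1.4-fold higher number from compound 3 to compound 4 (0.15 log units; within the scatter) on present data. In this assay the estimated value for compound 4 is 3000 nM within an expected range (1200 nM to 7500 nM).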

Compound 4, half-maximal inhibitory concentration: 680 nM
Estimate against measurement, compound 4: 4.4-fold (0.64 log units) above; measured number outside the range, below it.
By their numbers in this assay, from the lowest: compound 4; then compounds 3 and 1 (each within the scatter of the next); then compound 2.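

Notes on the substituent on an aromatic carbon, para to a large group, in this assay: ethoxy is the first group here to separate clearly from both hydrogen (a 5.7-fold lower number from compound 1 to compound 4 (0.76 log units; beyond the scatter)) and methyl (a 3.1-fold lower number from compound 3 to compound 4 (0.49 log units; beyond the scatter)), whereas methyl and hydrogen stayed within the scatter of each other. The spread at this one position also widens to a large step between iodo and ethoxy (a 12-fold lower number from compound 2 to compound 4 (1.09 log units; beyond the scatter)), so the read-out is more sensitive to this substituent than the three earlier compounds indicated, and compound 4 now has the lowest number of the set. No supporting data are available to explain why ethoxy differs from the other groups.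

The change from methyl to ethoxy adds both an oxygen and extra carbons, and the compounds shown do not separate these two contributions; methoxy and propyl at the same position would pull them apart. Going by these compounds, how far the trend extends also remains open, since a longer alkoxy chain such as butoxy, or an amine at this position, could continue it or reverse it.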